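The compounds below may be only part of what the source reports. "The series", "measured", "known", "first", "only" and "open" are said of these compounds alone.

Working notes on the series. The shared core appears in compound 1 `Cc1ccc(NC(=O)NC(=O)c2ccc(OCc3cccc(C(F)(F)F)c3)cc2)cc1-c1nc2ccccc2[nH]1`, compound 2 `Cc1ccc(COc2ccc(C(=O)NC(=O)Nc3ccc(C)c(-c4nc5ccccc5[nH]4)c3)cc2)cc1` and compound 3 `Cc1ccc(NC(=O)NC(=O)c2ccc(OCc3cccc(F)c3)cc2)cc1-c1nc2ccccc2[nH]1`, which differ only in the group on a saturated chain carbon bound to an oxygen on an aromatic ring. In a functional assay on HT-29 cells (Homo sapiens) for inhibition, read by MTT assay, with a stated time of 48 h (a lower number here means a stronger inhibitor, a higher number a weaker inhibitor), compound 1 gives 3520 nM, compound 2 gives 5110 nM and compound 3 gives 38200 nM. Compound 3 stands highest of the three: the step of an 11-fold higher number from compound 1 to compound 3 (1.04 log units; beyond the scatter) is large, the step of a 7.5-fold higher number from compound 2 to compound 3 (0.87 log units; beyond the scatter) is modest, while the step of a 1.5-fold higher number from compound 1 to compound 2 (0.16 log units; within the scatter) stays within the scatter.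

Compound 4 `Cc1ccc(NC(=O)NC(=O)c2ccc(OCc3ccc(Cl)cc3Cl)cc2)cc1-c1nc2ccccc2[nH]1` is the next step from compound 3: 2,4-dichlorophenyl in place of 3-fluorophenyl on a saturated chain carbon bound to an oxygen on an aromatic ring. Both measured steps that end at compound 3 show that replacing 3-fluorophenyl at this place with another substituted phenyl carries a sizeable change in this assay, and in both cases the substituted group other than 3-fluorophenyl gave the lower number. A 2,4-dichlorophenyl carrying two chlorine atoms is therefore expected to move the number down, in the direction of compound 1 and compound 2, by about a 7.6-fold lower number from compound 3 to compound 4 (0.88 log units; beyond the scatter). For compound 4 the estimate in this assay is 5000 nM, with a range from 1500 nM to 16000 nM.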

Compound 4, half-maximal inhibitory concentration: 2620 nM
The estimate for compound 4 lay 1.9-fold (0.28 log units) above the measured number; the range from low to high includes it.
By their numbers in this assay, from the lowest: compounds 4, 1 and 2 (each within the scatter of the next); then compound 3.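

In this assay the step of a 15-fold lower number from compound 3 to compound 4 (1.16 log units; beyond the scatter) is large, so a phenyl carrying two chlorine atoms at this place on a saturated chain carbon bound to an oxygen on an aromatic ring gives no penalty compared with compound 3. The steps of a 2.0-fold lower number from compound 2 to compound 4 (0.29 log units; within the scatter) and a 1.3-fold lower number from compound 1 to compound 4 (0.13 log units; within the scatter) both stay within the scatter, so 2,4-dichlorophenyl, 4-methylphenyl and 3-(trifluoromethyl)phenyl cannot be told apart here, and compound 3 alone stands apart from the other three. Nothing shown explains why 3-fluorophenyl stands apart.

The compounds shown leave open whether that gap follows the fluoro group itself or its place on the ring, which 4-fluorophenyl or unsubstituted phenyl would address. Also open, on these data alone, is how this position responds to a ring bearing an amine or a carboxylic acid.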